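This account rests on a few compounds, and the source may have more. Where it says the series, first, only, none or still open, it means among the compounds named here.

Compound 1 `CCCCCCCCCCCCCSC[C@H](NC(C)=O)C(=O)CCl` is the shortest chain in the set. In a functional assay on NALM-6 cells (Homo sapiens) (a lower number here means a stronger inhibitor, a higher number a weaker inhibitor), compound 1 gives only a limit, > 100000 nM. Compound 2 `CCCCCCCCCCCCCCCSC[C@H](NC(C)=O)C(=O)CCl` gives 8900 nM in this assay. The change ethyl in place of hydrogen on a saturated chain carbon, ten or more bonds along the chain from a sulfur made the step of an at least 11-fold lower number from compound 1 to compound 2 (1.05 log units; beyond the scatter). Compound 3 `CCCCCCCCCCCCCCCCCCCCSC[C@H](NC(C)=O)C(=O)CCl` again gives only a limit in this assay, > 100000 nM. Going on from compound 2 the step is an at least 11-fold higher number from compound 2 to compound 3 (1.05 log units; beyond the scatter). The cores of compound 1 and compound 3 differ by heptyl in place of hydrogen on a saturated chain carbon, ten or more bonds along the chain from a sulfur.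

Compound 4 `CCCCCCCCCCCCCCCCCCCCCCSC[C@H](NC(C)=O)C(=O)CCl` is not yet measured. It differs from compound 3 by ethyl in place of hydrogen on a saturated chain carbon, ten or more bonds along the chain from a sulfur, the same change as that from compound 1 to compound 2, at the same place. Since compound 3 already sits at the limit of > 100000 nM in this assay, at which 2 of the 3 values shown sit, and the step from compound 2 to compound 3 ran in the weaker direction, the expected step that the limit leaves unreadable from compound 3 to compound 4 is small or further weakening. Compound 4 is estimated at 200000 nM in this assay, with 40000 nM to 1000000 nM as its expected range.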

Compound 4, half-maximal inhibitory concentration: > 100000 nM
Compound 4: only a limit was reported; the forecaster's own chance of this, stated with the estimate: 85%; the middle value lies beyond the limit too.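

In this assay compound 4 gives > 100000 nM, which is a limit and not a number. The ethyl in place of hydrogen that produced an at least 11-fold lower number from compound 1 to compound 2 (1.05 log units; beyond the scatter) shows no readable effect on the core of compound 3: the steps from compound 3 to compound 4 and from compound 1 to compound 4 cannot be read, so carry-over of the change is neither shown nor excluded. Among the compounds shown here, the one readable new step is an at least 11-fold higher number from compound 2 to compound 4 (1.05 log units; beyond the scatter), which adds a second large step in the weaker direction from the only chain here with a numerical value.

As far as these compounds go, whether a chain of length between those of compound 2 and compound 3 gives a numerical value remains open. Also open, from the compounds shown here alone, is whether an amine or a carboxylic acid on the longest chains would bring a value inside the range of this assay.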